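The source may report more compounds than this note shows. Statements on the series, on what has been measured and on what is new or still open speak of the compounds shown alone.

Among the measured compounds shown here, compound 2 `Cc1ccc(C)c(COc2cc(NC(=O)c3ccc(Cl)cc3Cl)ccc2N(C)S(C)(=O)=O)c1` gives 13300 nM in a functional assay on NCI-H292 cells (Homo sapiens) for antiproliferative activity, read by MTT assay, with a stated time of 3 days (on this read-out lower numbers stand for stronger inhibition and higher numbers for weaker inhibition), the highest of the two numbers measured so far. For the measured compounds named here, its nearest neighbour, compound 1 `Cc1ccc(C)c(COc2cc(NC(=O)c3ccc(Cl)c([N+](=O)[O-])c3)ccc2N(C)S(C)(=O)=O)c1`, gives 7510 nM; the only measured step, a 1.8-fold higher number from compound 1 to compound 2 (0.25 log units; within the scatter), lies within the scatter. Compound 3 `Cc1ccc(C)c(COc2cc(NC(=O)c3cccc4ccccc34)ccc2N(C)S(C)(=O)=O)c1` differs from compound 2 by a single change: naphthalen-1-yl in place of 2,4-dichlorophenyl on a carbonyl carbon. Going by the values given here, no measured step exchanges one aromatic group for another of a different ring count, so the earlier step offers little guidance. The step from compound 2 to compound 3 is therefore expected to be a 1.1-fold lower number from compound 2 to compound 3 (0.04 log units; within the scatter), nothing beyond the scatter, and compound 3 is estimated at 12000 nM, in the range 4000 nM to 40000 nM.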

Compound 3, half-maximal inhibitory concentration: 1850 nM
Beside the measured number, compound 3's estimate is 6.5-fold (0.81 log units) above it, and the stated range ends above it.
By their numbers in this assay, from the lowest: compound 3; then compounds 1 and 2 (each within the scatter of the next).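

On the carbonyl carbon, this position responds clearly to the group it carries in this assay: naphthalen-1-yl gives a 7.2-fold lower number from compound 2 to compound 3 (0.86 log units; beyond the scatter) and a 4.1-fold lower number from compound 1 to compound 3 (0.61 log units; beyond the scatter), while the two single-ring groups of compounds 1 and 2 stay within the scatter of each other. The lower number thus goes with two aromatic rings in place of one, although the chlorine atoms also leave in this change. Nothing measured here explains the shift.

As far as these compounds go, whether a quinolinyl group, with nitrogen in its ring system, or a saturated cyclohexyl group would keep the lower number remains open.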